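Chloro in place of fluoro on the core of compound 1

The compounds below may be only part of what the source reports. "The series", "measured", "known", "first", "only" and "open" are said of these compounds alone.

Measured so far:
compound 1 `C[C@H](Nc1nc(N)nc(N)c1C#N)c1nn(-c2cccc(S(C)(=O)=O)c2)c2cc(F)ccc12`: 24%
compound 2 `C[C@H](Nc1ncnc2[nH]cnc12)c1nn(-c2cccnc2)c2cc(F)ccc12`: 23%

In a functional assay on HepG2 cells (Homo sapiens) for inhibition, read by sulforhodamine B assay, with a stated time of 72 h, tested at 10 uM (on this read-out higher numbers stand for more inhibition at the one concentration tested (going by the name of the read-out) and lower numbers for less inhibition), compound 1 gives 24%, and compound 2 gives 23%. The two numbers lie within the scatter of each other, so no order between them can be read; compound 1 merely shows the higher of the two numbers at hand. Compound 3 `C[C@H](Nc1nc(N)nc(N)c1C#N)c1nn(-c2cccc(S(C)(=O)=O)c2)c2cc(Cl)ccc12` has not been measured. It differs from compound 1 by chloro in place of fluoro on an aromatic carbon, on an aromatic carbon of a six-membered aromatic ring of carbon only, part of a fused system of two rings. Within the data shown here, no two measured compounds differ in a single place, so no comparable step is known. In this assay the step of a number 3 percentage points higher from compound 1 to compound 3 (within the scatter) is expected to be small, in no firm direction and probably not beyond the scatter. Compound 3 is estimated at 27%, with a range from 10% to 45%.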

Compound 3, a percentage reported as inhibition, at one concentration (the size of the read-out at that concentration, not a potency): 56%
The estimate for compound 3 lay 29 percentage points below the measured number, outside the stated range (above it).
By their numbers in this assay, from the lowest: compounds 2 and 1 (each within the scatter of the next); then compound 3.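

In this assay chloro in place of fluoro gives a number 32 percentage points higher from compound 1 to compound 3 (beyond the scatter) with the rest of the structure unchanged. This aromatic carbon of the six-membered aromatic ring of carbon only is therefore a place where exchanging one halogen for another moves the inhibition at the one concentration tested, something compound 1 and compound 2 could not show, since they differ in more than one place. Nothing at hand bears on what lies behind this step.

From the compounds shown here alone, whether the same exchange would carry over to the different groups of compound 2 remains open. Also open is how far the effect is particular to chloro, since bromo, methyl or a plain hydrogen on this carbon does not appear among the compounds shown.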